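A few compounds are considered here, and "the series" means these few. Any claim that something is new, unique, unknown or untested is made for them only; others in the source may bear on it.

Compound 1 `Cc1c(NC2=NCCN2)cccc1-c1ccccc1` is the parent of this short series. For the measured compounds named here, in an assay for binding affinity to Adrenergic receptor alpha-1 (Rattus norvegicus) (a higher number here means a weaker inhibitor, a lower number a stronger inhibitor), compound 1 gives 209 nM, the highest of the three numbers measured so far. Compound 2 `Cc1c(NC2=NCCN2)cccc1-c1cccc(Cl)c1`, in this assay, gives 132 nM, and compound 3 `Cc1c(NC2=NCCN2)cccc1-c1cccc(C#N)c1` gives 91.2 nM. The step from compound 1 to compound 2 is a 1.6-fold lower number from compound 1 to compound 2 (0.20 log units; within the scatter); the step from compound 1 to compound 3 is a 2.3-fold lower number from compound 1 to compound 3 (0.36 log units; beyond the scatter); between compound 2 and compound 3 the step is a 1.4-fold lower number from compound 2 to compound 3 (0.16 log units; within the scatter). Only the last of these three steps reaches beyond the scatter, and then only modestly.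

Compound 4 `Cc1c(NC2=NCCN2)cccc1-c1cccs1` takes a different direction: thiophen-2-yl in place of phenyl on an aromatic carbon. Going by the values given here, the three measured steps all keep the phenyl in place and vary what is carried on it; none of them exchanges the phenyl for another group, so no measured step bears directly on this change. The measured steps themselves were small, and the whole series spans a narrow range in this assay. The expectation is therefore a step from compound 1 to compound 4 of about a 1.2-fold lower number from compound 1 to compound 4 (0.06 log units; within the scatter), that is, no change beyond the scatter in either direction. For compound 4 in this assay the estimate is 180 nM, with a range from 70 nM to 450 nM.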

Compound 4, inhibition constant: 102 nM
Beside the measured number, compound 4's estimate is 1.8-fold (0.25 log units) above it; the range from low to high includes it.
By their numbers in this assay, from the lowest: compounds 3, 4, 2 and 1 (each within the scatter of the next, the first and the last beyond it).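

In this assay, the phenyl of compound 1 is not needed to hold the number at this position: thiophen-2-yl, a five-membered aromatic ring with 1 hetero atom, is accepted in its place, and the exchange gives a 2.0-fold lower number from compound 1 to compound 4 (0.31 log units; beyond the scatter). The aromatic ring itself, and not only what it carries, can therefore move the number at this place, ortho to a methyl group, although the step is modest and compound 4 stays within the scatter of both compound 2 and compound 3. Nothing available on these compounds accounts for this step.

Still open, as far as these compounds go, is whether the step depends on how the thiophene ring is attached or on the sulfur itself, which thiophen-3-yl, furan-2-yl or pyridin-3-yl at the same place would test, and whether chloro or cyano on the thiophen-2-yl adds to it as a further step. The compounds shown also say nothing about a saturated ring such as cyclohexyl, or about an amine or a carboxylic acid carried on the aromatic ring at this position.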